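Three Compounds at the Assay Limit and a Fourth Expected

The source may report more compounds than this note shows. Statements on the series, on what has been measured and on what is new or still open speak of the compounds shown alone.

Compound 1, `CCCOP(=O)(O)OCCSC(=S)N1CCCC1`, in an ADME assay on HEK293 cells (Homo sapiens) for inhibition, read by MTT assay, with stated times of 18 h and 4 h (a higher number here means a weaker inhibitor, a lower number a stronger inhibitor), gives only the limit > 100000 nM, not a number.
Compound 2, `CCCCCCOP(=O)(O)OCCSC(=S)N1CCCC1`, in this assay gives only the limit > 100000 nM.
Compound 3, `CCCCCCOP(=O)(O)OCCSC(=S)N1CCN(C)CC1`, in this assay gives only the limit > 100000 nM.

All three measured compounds stop at the same limit of this assay, so no difference between them can be read. From compound 2 to compound 1 the change is hydrogen in place of propyl on a saturated chain carbon, three bonds along the chain from an oxygen on an unsaturated carbon, and the step it made is a step that the two limits leave unreadable from compound 2 to compound 1. Compound 2 and compound 3 share the rest of their structure but differ in the core: 4-methylpiperazin-1-yl in place of pyrrolidin-1-yl on a thiocarbonyl carbon. The step that goes with it is a step that the two limits leave unreadable from compound 2 to compound 3. What is known on all three values is summed up in the evidence (the limit of > 100000 nM in this assay, at which 3 of the 3 values shown sit).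

Compound 4, `CCCOP(=O)(O)OCCSC(=S)N1CCN(C)CC1`, has not yet been measured. Going by the values given here, it arises from compound 3 by hydrogen in place of propyl on a saturated chain carbon, three bonds along the chain from an oxygen on an unsaturated carbon, the same change, at the same place, as the one from compound 2 to compound 1. The expected step from compound 3 to compound 4 is a step that the limit leaves unreadable from compound 3 to compound 4, which rests on the step that the two limits leave unreadable from compound 2 to compound 1 and on the evidence (the limit of > 100000 nM in this assay, at which 3 of the 3 values shown sit). For compound 4 in this assay the estimate is 150000 nM, expected to lie between 50000 nM and 500000 nM, with the outcome most likely being once more only a limit.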

Compound 4, half-maximal inhibitory concentration: 39600 nM
Compound 4: the middle estimate sits 3.8-fold (0.58 log units) above what was measured, outside the stated range (below it).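

In this assay, replacing hexyl with propyl on the core that carries 4-methylpiperazin-1-yl goes with an at least 2.5-fold lower number from compound 3 to compound 4 (0.40 log units; beyond the scatter), so on this core the chain change gives a stronger inhibitor, and the size is only a minimum, as the starting value is a limit. On the core that carries pyrrolidin-1-yl, the same change cannot be read, as both of its compounds stop at a limit, and the step between the two cores at the hexyl chain cannot be read either, so nothing here tells whether the change acts alike on both cores. One readable step therefore shows that this change can lower the number on one core, but it does not show that the effect carries over to the other, where the shared limit hides any difference: the limit of > 100000 nM in this assay, at which 3 of the 4 values shown sit.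

The compounds shown leave open whether the number follows chain length in a steady way, which a butyl or an ethyl chain in place of propyl could help to test. They also leave open how the propyl chain behaves with another group on the thiocarbonyl carbon, such as morpholin-4-yl or piperidin-1-yl.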